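The source may hold more compounds than are shown below. What is called first, only, known or untested is meant among the compounds shown, and "the series" means these compounds.

Working notes on the series. Three hydrazone analogues share one core. In an assay on isolated protein for inhibition of Maltase-glucoamylase (Homo sapiens), with a stated time of 15 min (a lower number here means a stronger inhibitor, a higher number a weaker inhibitor), compound 1 `COc1ccc(O)c(/C=N/NC(=O)c2ccc(-c3nc4ccccc4s3)cc2)c1` gives 6500 nM, compound 2 `O=C(N/N=C\c1ccccn1)c1ccc(-c2nc3ccccc3s2)cc1` gives 10200 nM, and compound 3 `O=C(N/N=C/c1cccs1)c1ccc(-c2nc3ccccc3s2)cc1` gives 8480 nM. Compound 3 stands second highest of the three numbers, its nearest neighbour being compound 2 and its furthest compound 1, both within the scatter. Compound 4 `COC(=O)c1ccc(/C=N/NC(=O)c2ccc(-c3nc4ccccc4s3)cc2)cc1` is not yet measured; it differs from compound 3 as follows: 4-(methoxycarbonyl)phenyl in place of thiophen-2-yl on a carbon with a double bond to nitrogen. The step from compound 1 to compound 3 bears on it, a 1.3-fold higher number from compound 1 to compound 3 (0.12 log units; within the scatter), as does a 1.2-fold lower number from compound 2 to compound 3 (0.08 log units; within the scatter); neither exceeded the scatter, so no step beyond the scatter is expected in this assay, a 1.2-fold lower number from compound 3 to compound 4 (0.08 log units; within the scatter). Compound 4 is expected near 7000 nM, between 3500 nM and 14000 nM.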

Compound 4, half-maximal inhibitory concentration: "not active" (no number reported)
Compound 4 has no reported number here; no gap can be computed for the estimate.
By their numbers in this assay, from the lowest: compounds 1, 3 and 2 (each within the scatter of the next).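

In this assay, among these compounds, compound 4 is reported as "not active" with no number, so no step from compound 3 to compound 4 can be read. The compounds shown leave open how far compound 4 lies from compound 3 in this assay. No evidence bears on this result.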